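This account rests on a few compounds, and the source may have more. Where it says the series, first, only, none or still open, it means among the compounds named here.

Measured in a functional assay on CHO cells for agonist activity at Free fatty acid receptor 2 (Homo sapiens), read by cAMP accumulation; on this read-out higher numbers stand for weaker inhibition and lower numbers for stronger inhibition:

Compound 1 `CC(C)[C@H](C(=O)NC(C)(C)C)c1ccc(Cl)cc1` gives > 100000 nM, a limit of the assay.
Compound 2 `CC(C)[C@H](C(=O)NCc1ccccc1)c1ccc(Cl)cc1` gives > 100000 nM, a limit of the assay.
Compound 3 `CC(C)[C@H](C(=O)Nc1ccccc1)c1ccc(Cl)cc1` gives > 100000 nM, a limit of the assay.

Compound 3 therefore stands at the limit of > 100000 nM in this assay, at which 3 of the 3 values shown sit, and no number separates it from compounds 1 and 2. The changes among the measured compounds all sit on the amide-type nitrogen: a step that the two limits leave unreadable from compound 1 to compound 2, a step that the two limits leave unreadable from compound 1 to compound 3 and a step that the two limits leave unreadable from compound 2 to compound 3. None of these steps has a readable size, so they give no measure of how far a substituent on that nitrogen can move the read-out.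

Compound 4 `CC(C)[C@H](C(=O)Nc1ccc(F)cn1)c1ccc(Cl)cc1` differs from compound 3 in one place: 5-fluoropyridin-2-yl in place of phenyl on an amide-type nitrogen. For the measured compounds named here, no measured step bears on this change with a readable size, so the direction is open; the shared limit of compounds 1, 2 and 3 makes it likely that compound 4 again ends at a limit, with a smaller chance of a measurable value. The step of an at least 1.6-fold lower number from compound 3 to compound 4 (0.22 log units; that floor lies within the scatter) is thus an expectation, not a reading. For compound 4 in this assay the estimate is 60000 nM, in a range from 5000 nM to 300000 nM.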

Compound 4, half-maximal inhibitory concentration: 1300 nM
Compound 4: the middle estimate sits 46-fold (1.66 log units) above what was measured; the measured number lies below the stated range.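

Compound 4 shows that the group on the amide-type nitrogen can move the read-out in this assay: the change gives an at least 76-fold lower number from compound 3 to compound 4 (1.88 log units; beyond the scatter), and the same holds for an at least 76-fold lower number from compound 2 to compound 4 (1.88 log units; beyond the scatter) and for an at least 76-fold lower number from compound 1 to compound 4 (1.88 log units; beyond the scatter). For the compounds shown here, each of these sizes is a floor, and the steps among compound 1, compound 2 and compound 3 cannot be read, so 5-fluoropyridin-2-yl is the only group on this nitrogen with a measured number. Compound 4 alone has left the limit: the limit of > 100000 nM in this assay, at which 3 of the 4 values shown sit.

The compounds shown do not tell whether the ring nitrogen, the fluorine or both together carry the change; a plain pyridin-2-yl and a fluorophenyl on the same nitrogen would separate them. On these data alone, how a chlorine or a methyl on the pyridine ring in place of the fluorine would read also remains open.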